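The source may report more compounds than this note shows. Statements on the series, on what has been measured and on what is new or still open speak of the compounds shown alone.

Measured compounds in a functional assay on the whole organism (artery, strain albino) with Rattus norvegicus as the target, with a stated time of 180 min, at a dose of 10 mg/kg by the oral route; on this read-out higher numbers stand for more inhibition at the one dose given (going by the name of the read-out) and lower numbers for less inhibition:

compound 1, `CC1=C(C(=O)Nc2ccc(F)cc2)C(c2ccc([N+](=O)[O-])cc2)N=C(SCc2ccccc2Cl)N1` — 12.4%
compound 2, `CC1=C(C(=O)Nc2ccc(F)cc2)C(c2ccc([N+](=O)[O-])cc2)N=C(SCc2cccc(Cl)c2)N1` — 11.9%
compound 3, `CC1=C(C(=O)Nc2ccc([N+](=O)[O-])cc2)C(c2ccc(Br)cc2)N=C(SCc2ccccc2Cl)N1` — 11.3%

All three numbers sit close together, and none of the gaps between them is large enough to count as a real difference in this assay. Compound 1 and compound 2 share a core and differ in one place only, (3-chlorophenyl in place of 2-chlorophenyl on a saturated chain carbon bound to a sulfur). The step that goes with this change, a number 0.5 percentage points lower from compound 1 to compound 2 (within the scatter), is small and gives no sign that the change moves the read-out either way. Compound 3 carries a different core; how the core of compound 3 differs from the core of compound 1 is not broken down here, so only the two values themselves can be set side by side, and they lie within the scatter of each other.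

Compound 4, `CC1=C(C(=O)Nc2ccc([N+](=O)[O-])cc2)C(c2ccc(Br)cc2)N=C(SCc2cccc(Cl)c2)N1`, is not yet measured. Among the measured compounds shown here, it differs from compound 3 by 3-chlorophenyl in place of 2-chlorophenyl on a saturated chain carbon bound to a sulfur, which is the same change as the one made from compound 1 to compound 2, at the same place on the saturated chain carbon bound to a sulfur. For the measured compounds named here, since the one measured instance of this change, a number 0.5 percentage points lower from compound 1 to compound 2 (within the scatter), stays within the scatter, the step from compound 3 to compound 4 is expected to be equally small, a number 0.3 percentage points lower from compound 3 to compound 4 (within the scatter). The estimate rests on a single measured pair and so carries a wide range. In this assay compound 4 is expected to give 11%, with the likely range from 3% to 19%.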

Compound 4, a percentage reported as inhibition, in the whole organism at one dose (the size of the read-out at that dose, not a potency): 9.3%
Compound 4: middle estimate off by 1.7 percentage points, on the high side; the measured number falls inside the stated range.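

In this assay, the exchange of 2-chlorobenzyl for 3-chlorobenzyl on the sulfur gives a number 2 percentage points lower from compound 3 to compound 4 (within the scatter) and so produces no real shift on this second core. Set beside the earlier instance, the step does not differ from it: the same change on two cores in this assay, a number 0.5 percentage points lower (within the scatter) from compound 1 to compound 2 and a number 2 percentage points lower (within the scatter) from compound 3 to compound 4, 1.5 percentage points apart, within the scatter of two such steps. On these two cores, then, the change carries over as a step too small to read, but that agreement is only the absence of a visible effect: it does not show that the change has an effect of its own in either direction, and two pairs say nothing about how it would behave on any other core.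

The sulfur substituents shown are limited to the two chlorobenzyl groups, so it remains open how the read-out responds to an unsubstituted benzyl, a longer chain such as phenylethyl, or a chain ending in an amine or a carboxylic acid at that place. Also open, from the compounds shown here alone, is whether any change at this place can move the read-out beyond the usual scatter at the single dose given, and whether the two cores would stay indistinguishable across a wider set of substituents.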